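Removing a methyl from two related cores: cytotoxicity in MT4 cells

A few compounds are considered here, and "the series" means these few. Any claim that something is new, unique, unknown or untested is made for them only; others in the source may bear on it.

The series is followed in an ADME assay on MT4 cells (Homo sapiens) for cytotoxicity, read by MTT assay; on this read-out lower numbers stand for higher toxicity in this test and higher numbers for lower toxicity in this test. Compound 1 `Cc1c(C(C)c2c(F)cccc2F)nc(Nc2ccc(C#N)cc2)[nH]c1=O` gives 1060 nM in this assay. Compound 2 `Cc1c(Cc2c(F)cccc2F)nc(Nc2ccc(C#N)cc2)[nH]c1=O` carries the change (hydrogen in place of methyl on a saturated chain carbon bound to two aromatic carbons). In this assay compound 2 reaches only a limit of the measurement, > 2830 nM, so its value is not a number. The step of an at least 2.6-fold higher number from compound 1 to compound 2 (0.42 log units; beyond the scatter) therefore marks the removal of the methyl as a move toward lower toxicity in this test, with the size of that move bounded only at one end (the limit of > 2830 nM in this assay, at which 1 of the 3 values shown sits).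

Compound 3 `Cc1c(Cl)nc(Nc2ccc(C#N)cc2)nc1C(C)c1c(F)cccc1F` has a different core; the difference between the two cores and the core of compound 1 is not broken down here. In this assay compound 3 also sits at a limit, > 13000 nM, again not a number but the ceiling of the measurement (the limit of > 13000 nM in this assay, at which 1 of the 3 values shown sits).

Compound 4 `Cc1c(Cl)nc(Nc2ccc(C#N)cc2)nc1Cc1c(F)cccc1F` is not yet measured in this assay. It differs from compound 3 by the change (hydrogen in place of methyl on a saturated chain carbon bound to two aromatic carbons), the same change as that from compound 1 to compound 2. Since compound 3 already stands at a limit, and since the earlier step of an at least 2.6-fold higher number from compound 1 to compound 2 (0.42 log units; beyond the scatter) went toward a higher number, compound 4 is expected to show at most a step that the limit leaves unreadable from compound 3 to compound 4 and most likely to return another limit rather than a number. For compound 4 the estimate in this assay is 25000 nM, with a range from 12000 nM to 70000 nM.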

Compound 4, half-maximal cytotoxic concentration: > 2690 nM
Compound 4: only a limit was reported; the forecaster's own chance of this, stated with the estimate: 85%; the middle value is on the limit's open side.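

Compound 4 returns only a limit, not a number: the limit of > 2690 nM in this assay, at which 1 of the 4 values shown sits. Compound 3 also stands at a limit: the limit of > 13000 nM in this assay, at which 1 of the 4 values shown sits. With both values being limits, no step can be read from compound 3 to compound 4. From the compounds shown here alone, what stays open is whether hydrogen in place of methyl on this core moves the number as it does from compound 1 to compound 2, and by how much.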